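A few compounds are considered here, and "the series" means these few. Any claim that something is new, unique, unknown or untested is made for them only; others in the source may bear on it.

Measured in a functional assay on PC-3 cells (Homo sapiens) for antiproliferative activity, read by MTT assay, with a stated time of 24 h; on this read-out higher numbers stand for weaker inhibition and lower numbers for stronger inhibition:
- Compound 1 `CCn1c(C(=O)NCC(=O)OC)ccc1C(CC)(CC)c1ccc(OCS(=O)(=O)c2ccccc2)c(C)c1`: > 50000 nM, a limit and not a number.
- Compound 2 `CCn1c(C(=O)NCCN)ccc1C(CC)(CC)c1ccc(OCS(=O)(=O)c2ccccc2)c(C)c1`: 6890 nM.
- Compound 3 `CCn1c(C(=O)N[C@@H](C)CO)ccc1C(CC)(CC)c1ccc(OCS(=O)(=O)c2ccccc2)c(C)c1`: 9520 nM.

Compound 3, at 9520 nM, stands within the scatter of compound 2. The only other result in the set, that of compound 1, is a limit. Compound 4 `CCn1c(C(=O)NCCO)ccc1C(CC)(CC)c1ccc(OCS(=O)(=O)c2ccccc2)c(C)c1` is the next to be examined in this assay. It differs from compound 3 at one place: hydrogen in place of methyl on a saturated chain carbon bound to an amide-type nitrogen and a saturated chain carbon. This is hydrogen in place of methyl on a saturated chain carbon bound to an amide-type nitrogen and a saturated chain carbon, turning 1-(hydroxymethyl)ethyl into 2-hydroxyethyl.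

Two measured steps start from a limit, the limit of > 50000 nM in this assay, at which 1 of the 3 values shown sits: an at least 7.2-fold lower number from compound 1 to compound 2 (0.86 log units; beyond the scatter) and an at least 5.2-fold lower number from compound 1 to compound 3 (0.72 log units; beyond the scatter). Both lie beyond the scatter, but both remove the methoxycarbonyl group, which compound 4 does not carry. The closer guide is a 1.4-fold higher number from compound 2 to compound 3 (0.14 log units; within the scatter), a swap of 1-(hydroxymethyl)ethyl for 2-aminoethyl on the amide-type nitrogen that stays within the scatter. No step beyond the scatter is therefore expected from the smaller change at hand. The expected step is a 1.1-fold lower number from compound 3 to compound 4 (0.02 log units; within the scatter). The estimate for compound 4 is 9000 nM, with an expected range from 4000 nM to 22000 nM.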

Compound 4, half-maximal inhibitory concentration: 17700 nM
Beside the measured number, compound 4's estimate is 2.0-fold (0.29 log units) below it; the range from low to high includes it.
By their numbers in this assay, from the lowest: compounds 2, 3 and 4 (each within the scatter of the next, the first and the last beyond it). At a limit, above all of these: compound 1.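

In this assay, taking the methyl off the chain carbon bound to the amide-type nitrogen turns 1-(hydroxymethyl)ethyl into 2-hydroxyethyl and gives a 1.9-fold higher number from compound 3 to compound 4 (0.27 log units; within the scatter), so this position accepts hydrogen in place of methyl without a change that can be told from the scatter. For the compounds shown here, compound 4 also supplies the first comparison in which the chain stays the same and only its end group differs, which compounds 2 and 3 could not give, and hydroxy in place of amino yields a 2.6-fold higher number from compound 2 to compound 4 (0.41 log units; beyond the scatter), a modest step beyond the scatter that favours the amino end. The remaining comparison, with hydroxymethyl in place of methoxycarbonyl, is an at least 2.8-fold lower number from compound 1 to compound 4 (0.45 log units; beyond the scatter), and this gives only a bound and not a size, as compound 1 rests at a limit: the limit of > 50000 nM in this assay, at which 1 of the 4 values shown sits.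

The compounds shown leave open how a longer chain, or a carboxylic acid in place of the hydroxy, would read in this assay. They also leave open whether the amino end of compound 2 would respond to an added methyl as the hydroxy end does, and how the mirror-image form of 1-(hydroxymethyl)ethyl would compare.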